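The source may report more compounds than this note shows. Statements on the series, on what has been measured and on what is new or still open speak of the compounds shown alone.

Working notes on the series.

Compound 1 `C=C1C[C@]23C[C@@]1(O)CC[C@H]2c1cc(Br)c(O)c(C)c1[C@@H]3Cn1cc(-c2ccccc2)nn1` and compound 3 `C=C1C[C@]23C[C@@]1(O)CC[C@@H]2c1cccc(C)c1[C@@H]3Cn1cc(-c2ccccc2)nn1` share the triazole-linked phenyl group, while the difference between the two cores is not broken down here. In a functional assay on MCF7 cells (Homo sapiens) for cytotoxicity, read by MTT assay, with a stated time of 4 days (a higher number here means a weaker inhibitor, a lower number a stronger inhibitor), compound 1 gives only a limit of the assay, > 20000 nM. Compound 2 `C=C1C[C@]23C[C@@]1(O)CC[C@H]2c1cc(Br)c(O)c(C)c1[C@@H]3Cn1cc(-c2ccc(F)cc2)nn1` carries the change (fluoro in place of hydrogen on an aromatic carbon), and in this assay compound 2 gives 19200 nM. The measured step is an at least 1.0-fold lower number from compound 1 to compound 2 (0.01 log units; that floor lies within the scatter); it rests on (the limit of > 20000 nM in this assay, at which 2 of the 3 values shown sit), so its true size is not known.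

Compound 3 in this assay also gives only a limit, > 20000 nM. Compound 4 `C=C1C[C@]23C[C@@]1(O)CC[C@@H]2c1cccc(C)c1[C@@H]3Cn1cc(-c2ccc(F)cc2)nn1` carries the same kind of change, (fluoro in place of hydrogen on an aromatic carbon), made on the core of compound 3; the two place lines read the same word for word.

Expected outcome for compound 4: from compound 3 the step is estimated as a step that the limit leaves unreadable from compound 3 to compound 4, because the only measured instance of this change, an at least 1.0-fold lower number from compound 1 to compound 2 (0.01 log units; that floor lies within the scatter), moved the value by no more than the scatter and started from a limit. Compound 4 is therefore expected to come out near 25000 nM in this assay, most likely again as a limit rather than a number.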

Compound 4, half-maximal inhibitory concentration: > 20000 nM
Compound 4: only a limit was reported; the forecaster's own chance of this, stated with the estimate: 70%; the middle value is on the limit's open side.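

In this assay compound 4 gives only a limit (> 20000 nM). Compound 3 also stands at a limit, so no step can be read between compound 3 and compound 4: the limit of > 20000 nM in this assay, at which 3 of the 4 values shown sit.

The compounds shown leave open how far phenyl to 4-fluorophenyl truly moves the value on either core.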